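Hydroxybutyl for phenyl on two cores: growth inhibition notes

The source may report more compounds than this note shows. Statements on the series, on what has been measured and on what is new or still open speak of the compounds shown alone.

Compound 3 `CSc1nc(NCc2ccccc2)c2cccnc2n1` and compound 1 `CSc1nc(NCCCCCO)c2cccnc2n1` share one core. In a functional assay on HT-29 cells (Homo sapiens) for cytotoxicity, read by MTT assay, with a stated time of 72 h (on this read-out lower numbers stand for stronger inhibition of growth and higher numbers for weaker inhibition of growth), compound 3 gives only a limit of the assay, > 100000 nM. In this assay compound 1 likewise gives only a limit, > 100000 nM. The change between them is 4-hydroxybutyl in place of phenyl on a saturated chain carbon bound to a nitrogen on an aromatic ring and its step that the two limits leave unreadable from compound 3 to compound 1 cannot be sized because of the limit of > 100000 nM in this assay, at which 3 of the 3 values shown sit. Compound 2 `CSc1nc(NCc2ccccc2)c2ccccc2n1` carries a different core; the difference between the two cores is not broken down here. In this assay compound 2 gives only a limit, > 100000 nM. Compound 4 `CSc1nc(NCCCCCO)c2ccccc2n1` is not yet measured and differs from compound 2 by 4-hydroxybutyl in place of phenyl on a saturated chain carbon bound to a nitrogen on an aromatic ring, the same change as before. The step of a number no higher from compound 2 to compound 4 (the limit leaves the size open) is expected to be flat, resting on compound 3 and compound 1 at the limit of > 100000 nM in this assay, at which 3 of the 3 values shown sit. Compound 4 is therefore expected to sit near 100000 nM, between 40000 nM and 300000 nM, most probably again reported only as a limit.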

Compound 4, concentration for total growth inhibition: > 100000 nM
Compound 4: only a limit was reported (the forecaster's own chance of this, stated with the estimate: 85%); the middle value sits exactly at the limit.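

No step can be read between compound 2 and compound 4, since both are reported only as limits: the limit of > 100000 nM in this assay, at which 4 of the 4 values shown sit. From the compounds shown here alone, the size of the 4-hydroxybutyl for phenyl change on either core remains open.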